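Chloro in Place of Trifluoromethyl on a Pyrazole Urea

This account rests on a few compounds, and the source may have more. Where it says the series, first, only, none or still open, it means among the compounds named here.

Compound 2, `O=C(Nc1cccc(-n2cc(-c3ccncc3)c(-c3cc(O)cc(Cl)c3)n2)c1)Nc1ccc(Cl)c(C(F)(F)F)c1`, was tested in a functional assay on A549 cells (Homo sapiens) for inhibition, read by sulforhodamine B assay, with a stated time of 48 h, tested at 10 uM (on this read-out lower numbers stand for a stronger effect and higher numbers for a weaker effect at the one concentration tested), and gave 8.81%. Compound 1, `COc1cc(Cl)cc(-c2nn(-c3cccc(NC(=O)c4ccc(Cl)c(Cl)c4)c3)cc2-c2ccncc2)c1`, gives 59.7% in this assay. Compound 2 therefore stands as the lower of the two numbers on this read-out, and its distance to compound 1 lies beyond the usual scatter. Compound 3, `O=C(Nc1cccc(-n2cc(-c3ccncc3)c(-c3cc(O)cc(Cl)c3)n2)c1)Nc1ccc(Cl)c(Cl)c1`, has not yet been measured. It differs from compound 2 in one place: chloro in place of trifluoromethyl on an aromatic carbon. Among the compounds with values here, no step between measured compounds carries this change, so its effect on the read-out cannot be read from the numbers at hand. Since the group that leaves and the group that enters each bring no hydrogen-bond donor or acceptor and the rest of compound 2 is kept, the step is expected to be small. Compound 3 is expected to give about 15%, within 4% to 35%, in this assay. The expected step of a number 6.2 percentage points higher from compound 2 to compound 3 (within the scatter) is estimated to lie within the scatter, if anything toward a slightly weaker effect.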

Compound 3, a percentage reported as activity, at one concentration (the size of the read-out at that concentration, not a potency): 3.96%
Estimate against measurement, compound 3: 11 percentage points above, and the stated range ends above it.
By their numbers in this assay, from the lowest: compounds 3 and 2 (each within the scatter of the next); then compound 1.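

In this assay, chloro in place of trifluoromethyl gives a number 4.9 percentage points lower from compound 2 to compound 3 (within the scatter), the first step read at this position, which is ortho to a chloro group and meta to a large group. At the one concentration tested, then, 3,4-dichlorophenyl and 4-chloro-3-(trifluoromethyl)phenyl cannot be told apart, although chloro brings a single heavy atom where trifluoromethyl brings four, something compound 1 could not show since it differs from compound 2 in more than one place. Nothing at hand offers a reason for this outcome.

Still open, from the compounds shown here alone, is how this position would respond to a group of another kind, such as an amine, a nitrile or a carboxylic acid. Equally open, going by these compounds, is whether the same change would read alike on the rest of compound 1, and how compound 2 and compound 3 compare at other concentrations.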